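The source may report more compounds than this note shows. Statements on the series, on what has been measured and on what is new or still open speak of the compounds shown alone.

Compound 3 `COc1nc(C)c(Nc2nc(Cl)cn([C@H](COC(=O)Nc3ccc(Cl)cc3Cl)C3CC3)c2=O)cc1C` stands second highest of the three numbers in an assay on frontal cortex for displacement of a labelled ligand from corticotropin-releasing factor receptor 1 (Rattus norvegicus), with a stated time of 2 h (a lower number here means a stronger inhibitor, a higher number a weaker inhibitor), where compound 3 gives 1.7 nM. Compound 2 `COc1nc(C)c(Nc2nc(Cl)cn([C@H](COC(=O)Nc3ccccc3)C3CC3)c2=O)cc1C` gives 1.5 nM, and compound 1 `COc1nc(C)c(Nc2nc(Cl)cn([C@H](COC(C)=O)C3CC3)c2=O)cc1C` gives 5.3 nM. Compound 4 `COc1nc(C)c(Nc2nc(Cl)cn([C@H](COc3ccccn3)C3CC3)c2=O)cc1C` differs from compound 3 by pyridin-2-yl in place of (2,4-dichlorophenyl)carbamoyl on an oxygen on a saturated carbon. For the measured compounds named here, the steps that bear on this are a 3.1-fold lower number from compound 1 to compound 3 (0.49 log units; beyond the scatter) and a 3.5-fold lower number from compound 1 to compound 2 (0.55 log units; beyond the scatter), which both accompanied the arrival of an arylcarbamoyl group, while a 1.1-fold higher number from compound 2 to compound 3 (0.05 log units; within the scatter) shows that the choice of aryl group lay within the scatter. Going by the values given here, no measured step tests an aryl ether in this position, so the expectation sits between compound 1 and compound 3. Compound 4 is therefore expected to give 4 nM, within a range from 1.5 nM to 12 nM. This estimate corresponds to an expected 2.4-fold higher number from compound 3 to compound 4 (0.37 log units; beyond the scatter).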

Compound 4, half-maximal inhibitory concentration: 1.2 nM
Beside the measured number, compound 4's estimate is 3.3-fold (0.52 log units) above it; the measured number lies below the stated range.
By their numbers in this assay, from the lowest: compounds 4, 2 and 3 (each within the scatter of the next); then compound 1.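

In this assay, pyridin-2-yl on this oxygen matches the arylcarbamoyl groups, with a 1.4-fold lower number from compound 3 to compound 4 (0.15 log units; within the scatter) and a 1.3-fold lower number from compound 2 to compound 4 (0.10 log units; within the scatter), so the carbonyl and the amide hydrogen of those groups are not required for a low number here. Against acetyl, the same change gives a 4.4-fold lower number from compound 1 to compound 4 (0.65 log units; beyond the scatter), so this oxygen tolerates an aromatic ring joined directly as well as one joined through a carbamoyl link. Nothing measured here explains these steps. The compounds shown leave open whether the ring nitrogen of pyridin-2-yl matters, which a plain phenyl ether would test, and whether a saturated ring such as piperidine on this oxygen would serve equally.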